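This account rests on a few compounds, and the source may have more. Where it says the series, first, only, none or still open, it means among the compounds named here.

Three compounds have been measured in a toxicity assay on MDCK cells (Canis lupus familiaris) for cytotoxicity, read by crystal violet staining, with a stated time of 48 h; on this read-out higher numbers stand for lower toxicity in this test and lower numbers for higher toxicity in this test:
Compound 1, `Cc1ccc2[nH]c(=O)c(CN(Cc3ccc(C(C)(C)C)cc3)C(C)c3ccc(N(C)C)c(Cl)c3)cc2c1`, gives 9800 nM.
Compound 2, `COc1ccc(C(C)N(Cc2ccc(C(C)(C)C)cc2)Cc2cc3cc(C4CC4)ccc3[nH]c2=O)cc1Cl`, gives only a limit of the assay, > 10000 nM.
Compound 3, `CC(c1ccc(N(C)C)c(Cl)c1)N(Cc1ccc(C(C)(C)C)cc1)Cc1cc2cc(C3CC3)ccc2[nH]c1=O`, likewise gives only a limit of the assay, > 10000 nM.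

Compound 3 thus stands without a number of its own in this assay; it sits at the limit of > 10000 nM in this assay, at which 2 of the 3 values shown sit. The step of an at least 1.0-fold higher number from compound 1 to compound 3 (0.00 log units; that floor lies within the scatter), cyclopropyl in place of methyl on an aromatic carbon, gives only a floor. The step that the two limits leave unreadable from compound 2 to compound 3, dimethylamino in place of methoxy on an aromatic carbon, cannot be sized at all, as both ends are limits.

Compound 4, `CC(c1ccc(OC(F)(F)F)c(Cl)c1)N(Cc1ccc(C(C)(C)C)cc1)Cc1cc2cc(C3CC3)ccc2[nH]c1=O`, differs from compound 3 by trifluoromethoxy in place of dimethylamino on an aromatic carbon. For the measured compounds named here, no measured step reads out a change at this aromatic carbon. Compound 2, which carries methoxy there, sits at the limit. Compound 3, which carries dimethylamino there, sits at the limit as well. On that basis compound 4 is expected to show no step beyond the scatter, a step that the limit leaves unreadable from compound 3 to compound 4, and most likely to return a limit once more. The estimate for compound 4 in this assay is 12000 nM, with a range from 5000 nM to 30000 nM.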

Compound 4, half-maximal cytotoxic concentration: > 10000 nM
Compound 4: no number, only a limit; the forecaster's own chance of this, stated with the estimate: 70%; the middle value is on the limit's open side.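

In this assay compound 4 gives > 10000 nM, which is a limit of the assay and not a number. The steps to it from compound 2 and from compound 3 therefore cannot be read: the limit of > 10000 nM in this assay, at which 3 of the 4 values shown sit. The compounds shown leave open whether methoxy, dimethylamino and trifluoromethoxy on this aromatic carbon differ at all in this read-out.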